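Swapping the amide aryl group in a thiazole series

The source may report more compounds than this note shows. Statements on the series, on what has been measured and on what is new or still open speak of the compounds shown alone.

Measured so far:
Compound 1, `CCOC(=O)c1sc(-c2cccc(NC(=O)c3ccc(C(F)(F)F)cc3)c2)nc1Nc1ccc(N2CCN(C)CC2)cc1` — 18.4%
Compound 2, `CCOC(=O)c1sc(-c2cccc(NC(=O)c3ccc(Cl)cc3)c2)nc1Nc1ccc(N2CCN(C)CC2)cc1` — 46.9%

Compound 1 and compound 2 share one core and differ only in the group on the benzamide ring. In a functional assay on Ramos cells (Homo sapiens) for antiproliferative activity, read by CCK-8 assay, with a stated time of 72 h, tested at 40 uM (a lower number here means less inhibition, a higher number more inhibition at the concentration tested (going by the name of the read-out)), compound 1 gives 18.4%, and compound 2 gives 46.9%. Within the data shown here, the single step on record, a number 28.5 percentage points higher from compound 1 to compound 2 (beyond the scatter), leaves compound 2 as the higher of the two numbers, with compound 1 the nearest value below it.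

Compound 3, `CCOC(=O)c1sc(-c2cccc(NC(=O)c3ccco3)c2)nc1Nc1ccc(N2CCN(C)CC2)cc1`, has not yet been measured. It differs from compound 2 as furan-2-yl in place of 4-chlorophenyl on a carbonyl carbon. Among the measured compounds shown here, no measured step covers an exchange of this kind: the one known step concerns a substituent on the same aryl ring, not replacement of the ring itself, so it offers little guidance on direction. The size of that step shows that changes at this position can move this assay beyond the scatter. Compound 3 is therefore expected to fall a little below compound 2, a step of a number 14.9 percentage points lower from compound 2 to compound 3 (beyond the scatter), with the estimate for compound 3 at 32% and a range from 10% to 58%.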

Compound 3, a percentage reported as inhibition, at one concentration (the size of the read-out at that concentration, not a potency): 50.2%
For compound 3 the middle estimate is 18.2 percentage points below the measured one, and the stated range covers the measured number.
By their numbers in this assay, from the lowest: compound 1; then compounds 2 and 3 (each within the scatter of the next).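

Replacing the whole aryl ring on this carbonyl carbon need not change the read-out: in this assay the exchange of 4-chlorophenyl for furan-2-yl gives a number 3.3 percentage points higher from compound 2 to compound 3 (within the scatter) and so leaves the two groups indistinguishable here, although the ring size and the hetero atom both differ. The exchange of 4-(trifluoromethyl)phenyl for furan-2-yl gives a number 31.8 percentage points higher from compound 1 to compound 3 (beyond the scatter) and so, among these three, only the trifluoromethyl-bearing group stands apart, while a six-membered carbon ring as such does not set the number. No measurement shown here explains why these groups behave as they do. On these data alone, whether a pyridine ring, a saturated ring such as piperidine or a plain alkyl chain on the same carbonyl carbon would keep the number at this level remains open. So does whether the parity of the chlorophenyl and furan amides would hold at concentrations other than the single one tested.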